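Thiophene for pyridine on a shared core without a baseline

The source may hold more compounds than are shown below. What is called first, only, known or untested is meant among the compounds shown, and "the series" means these compounds.

Compound 1 `Oc1ccc(-c2cc(-c3cccnc3)nc(-c3ccccc3Cl)c2)cc1` carries a pyridin-3-yl group, a 2-chlorophenyl group and a 4-hydroxyphenyl group on its core. For compound 1 the record in an ADME assay on HEK293 cells (Homo sapiens) for cytotoxicity, read by CCK-8 assay and cell counting, with a stated time of 2 days (a lower number here means a stronger inhibitor, a higher number a weaker inhibitor), reads "not determined" (no result reported), so no single number stands for it, and where it sits among the measured compounds cannot be said. Among the measured compounds shown here, the only measured member of the set is compound 2 `Oc1cccc(-c2cc(-c3cccc(Cl)c3)nc(-c3ccco3)c2)c1`, which in this assay gives 2530 nM; compound 2 differs from compound 1 in more than one place, so no step between them can be set out.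

Compound 3 `Oc1ccc(-c2cc(-c3ccsc3)nc(-c3ccccc3Cl)c2)cc1` is reached from compound 1 by one change, (thiophen-3-yl in place of pyridin-3-yl on an aromatic carbon). With no number for compound 1, the size of this step in this assay cannot be computed, and no direction is expected beyond the usual scatter. Resting the expectation on compound 2 and its 2530 nM, compound 3 is estimated to give about 3000 nM in this assay, with a range from 800 nM to 12000 nM.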

Compound 3, half-maximal inhibitory concentration: 5930 nM
The estimate for compound 3 lay 2.0-fold (0.30 log units) below the measured number; the measured number falls inside the stated range.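

No new step can be read from this result: in this assay no single number stands for compound 1, and compound 2 differs from compound 3 in more than one place. The compounds shown leave open whether thiophen-3-yl in place of pyridin-3-yl moves the value in this assay at all. Nothing given here explains the value of compound 3.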